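The compounds below may be only part of what the source reports. "The series", "measured", "known", "first", "only" and "open" are said of these compounds alone.

Measured so far in a functional assay on KBVIN cells (Homo sapiens) for cytotoxicity, read by sulforhodamine B assay; on this read-out lower numbers stand for stronger inhibition of growth and higher numbers for weaker inhibition of growth:
Compound 1 `Cc1ccc2c(c1)CCCN2c1nc(Cl)nc2ccccc12` gives 46 nM
Compound 2 `Cc1ccc2c(c1)CCCN2c1nc(C)nc2ccccc12` gives 176 nM
Compound 3 `COc1ccc2c(c1)CCCN(c1nc(Cl)nc3ccccc13)C2` gives 5450 nM

Of these three, compound 3 carries the highest number by a wide margin, with compound 2 at 176 nM and compound 1 at 46 nM on the same scale. Its core also differs from the core of compound 1.

Compound 4 `COc1ccc2c(c1)CCCN(c1nc(C)nc3ccccc13)C2` keeps the core of compound 3 and changes one group, as counted in methyl in place of chloro on an aromatic carbon and described as methyl in place of chloro on an aromatic carbon. That carbon sits on the six-membered aromatic ring with 2 nitrogen, between two ring nitrogen atoms.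

Going by the values given here, only one measured step bears on this change. The same exchange gave a 3.8-fold higher number from compound 1 to compound 2 (0.58 log units; beyond the scatter) on the other core, a modest step that lies beyond the scatter. A single step on a different core is thin evidence, so the size may not carry over, but a modest rise in the number is the expectation in this assay for this exchange too. The estimated change is a 3.1-fold higher number from compound 3 to compound 4 (0.49 log units; beyond the scatter) in this read-out. For compound 4 the expected value is 17000 nM with an estimated range from 5500 nM to 50000 nM in this read-out.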

Compound 4, concentration for 50% growth inhibition: 14800 nM
For compound 4 the middle estimate is 1.1-fold (0.06 log units) above the measured one, and the stated range covers the measured number.
By their numbers in this assay, from the lowest: compound 1; then compound 2; then compound 3; then compound 4.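

In this assay, methyl in place of chloro on the aromatic carbon between two ring nitrogen atoms gives a 2.7-fold higher number from compound 3 to compound 4 (0.43 log units; beyond the scatter), so the direction of the earlier step now holds on a second core. Before this pair, the exchange had been seen only once, and its size on any other core was an open question. The two steps now agree in direction and also in size, as far as the scatter allows: the same change on two cores in this assay, a 3.8-fold higher number (0.58 log units; beyond the scatter) from compound 1 to compound 2 and a 2.7-fold higher number (0.43 log units; beyond the scatter) from compound 3 to compound 4, 1.4-fold (0.15 log units) apart, within the scatter of two such steps

The compounds shown cover only chloro and methyl at this carbon, so they leave open whether an amine, a nitrile or a longer chain there would give a lower or higher number than either group, and on either core. Going by these compounds alone, they also leave open whether the agreement extends to cores beyond these two, and, with only two pairs in a single cell line, nothing here tells why the exchange has this effect or whether it would look the same in this assay for other substituents elsewhere on the shared core.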